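Dimethylamino for Methanesulfonamido on the Aryl Ring

This account rests on a few compounds, and the source may have more. Where it says the series, first, only, none or still open, it means among the compounds named here.

The compounds here share one core and differ in the amide-bound amine and in the aromatic ring attached to it. Compound 1 `CS(=O)(=O)Nc1ccc(-c2cc(C(=O)N[C@H]3CCCNC3)c(NC(N)=O)s2)cc1` carries a methanesulfonamido group on that ring. In a functional assay on HT-29 cells (Homo sapiens) (a higher number here means that more compound is needed for the effect, a lower number that less compound is needed), compound 1 gives 2200 nM. Compound 2 `CNCCNC(=O)c1cc(-c2ccccc2)sc1NC(N)=O`, which has an unsubstituted ring and a different amine on the amide, gives 580 nM in this assay. For compound 3 `NC(=O)Nc1sc(-c2ccccc2)cc1C(=O)NCC1CNCCO1` the entry in this assay reads "not determined" (no result reported), so no result was obtained. Of the two numbers available, compound 1 is the highest, and the gap to compound 2 lies beyond the usual scatter of the measurement.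

Compound 4 `CN(C)c1ccc(-c2cc(C(=O)N[C@H]3CCCNC3)c(NC(N)=O)s2)cc1` has not been measured. It differs from compound 1 in one place: dimethylamino in place of methanesulfonamido on an aromatic carbon. For the measured compounds named here, no pair of measured compounds shows the effect of this exchange, so the expectation rests on the range the two numbers span. The step is estimated as a 1.5-fold lower number from compound 1 to compound 4 (0.17 log units; within the scatter), a small shift toward a lower number. Compound 4 is therefore estimated to give 1500 nM in this assay, with a likely range from 400 nM to 6000 nM.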

Compound 4, half-maximal effective concentration: 90 nM
Beside the measured number, compound 4's estimate is 17-fold (1.22 log units) above it; the whole stated range lies above it.
By their numbers in this assay, from the lowest: compound 4; then compound 2; then compound 1.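

In this assay the exchange of methanesulfonamido for dimethylamino on the aromatic carbon para to a large group gives a 24-fold lower number from compound 1 to compound 4 (1.39 log units; beyond the scatter) and so shows that the group at this position alone can move the number by a large margin. For the compounds shown here, the earlier compounds differed both on the aromatic ring and in the amine on the amide, so they could not separate the two, whereas here only this one group changes and the whole step belongs to the exchange. The change takes away a sulfur, two oxygens and a hydrogen-bond donor in one move, so this pair cannot tell which of these differences counts, and nothing at hand bears on why the step is so large.

Going by these compounds alone, it remains open whether the same exchange gives a step of similar size with the amine on the amide of compound 2 in place of the one shared by compound 1 and compound 4. Also open, from the compounds shown here alone, is how a primary amino group, a diethylamino group or a methoxy group would compare with dimethylamino at this same position.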